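The compounds below may be only part of what the source reports. "The series", "measured", "known", "first", "only" and "open" are said of these compounds alone.

Measured compounds:
compound 1 `Brc1ccc2ccn(CCN3CCCN4CCCCC4C3)c2c1`, 3 nM
compound 2 `CN1CCCN(CCn2ccc3cc(Br)ccc32)CC1`, 88 nM
compound 3 `C#Cc1ccc2ccn(CCN3CCCN(C)CC3)c2c1`, 140 nM

In an assay on HEK293 cells for binding affinity to 5-hydroxytryptamine receptor 7 (Homo sapiens), read by radioligand binding (on this read-out higher numbers stand for weaker inhibition and lower numbers for stronger inhibition), compound 3 gives the highest of the three numbers. Compound 2 sits nearest, and the gap between the two lies within the scatter, so the two cannot be told apart. Compound 1 sits furthest away, with a far lower number that lies beyond the scatter.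

Compound 4 `CN1CCCN(CCn2ccc3ccc(-c4ccsc4)cc32)CC1` is not yet measured. It differs from compound 3 in one place: thiophen-3-yl in place of ethynyl on an aromatic carbon. Going by the values given here, no pair of measured compounds shows such a swap, so the size of the step is open. A small move toward a lower number seems plausible, though a change within the scatter is just as likely. For compound 4 the expected value in this assay is 60 nM, with a range from 15 nM to 250 nM, which would mean a step of a 2.3-fold lower number from compound 3 to compound 4 (0.37 log units; beyond the scatter).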

Compound 4, inhibition constant: 109 nM
Compound 4: middle estimate off by 1.8-fold (0.26 log units), on the low side; the measured number falls inside the stated range.
By their numbers in this assay, from the lowest: compound 1; then compounds 2, 4 and 3 (each within the scatter of the next).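

In this assay putting thiophen-3-yl in place of ethynyl on this aromatic carbon gives a 1.3-fold lower number from compound 3 to compound 4 (0.11 log units; within the scatter) and so the two compounds cannot be told apart. Going by these compounds alone, at this position, then, a five-membered aromatic ring containing sulfur reads the same as the smaller ethynyl group, a point no earlier compound could show. Nothing available here offers an explanation for this result. On these data alone, whether an amine or a carboxylic acid on this same carbon would also leave the number unmoved stays open.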